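This account rests on a few compounds, and the source may have more. Where it says the series, first, only, none or still open, it means among the compounds named here.

Working notes on the series in a functional assay on the whole organism (artery, strain albino) with Rattus norvegicus as the target, with a stated time of 720 min, at a dose of 10 mg/kg by the oral route; a lower number here means less inhibition, a higher number more inhibition at the dose given (going by the name of the read-out). Compound 1 `CC1=C(C(=O)Nc2ccc(F)cc2)C(c2ccc([N+](=O)[O-])cc2)N=C(SCc2ccccc2)N1` gives 27.3%, compound 2 `CC1=C(C(=O)Nc2ccc(F)cc2)C(c2ccc([N+](=O)[O-])cc2)N=C(SCc2ccc(Cl)cc2)N1` gives 22.2%, and compound 3 `CC1=C(C(=O)Nc2ccc(Br)cc2)C(c2ccc(Cl)cc2Cl)N=C(SCc2ccccc2)N1` gives 11.3%, the lowest of the three numbers, with compound 2 the nearest of the other two and compound 1 the furthest, both beyond the scatter. Compound 4 `CC1=C(C(=O)Nc2ccc(Br)cc2)C(c2ccc(Cl)cc2Cl)N=C(SCc2cccc(Cl)c2)N1` is not yet measured. It differs from compound 3 by chloro in place of hydrogen on an aromatic carbon. Within the data shown here, the one measured step of the same kind is a number 5.1 percentage points lower from compound 1 to compound 2 (within the scatter), which lies within the scatter. On that basis no step beyond the scatter is expected in this assay in either direction. The step expected here is a number 3.3 percentage points lower from compound 3 to compound 4 (within the scatter). Compound 4 is therefore estimated at 8%, with a range from 0% to 22%.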

Compound 4, a percentage reported as inhibition, in the whole organism at one dose (the size of the read-out at that dose, not a potency): 11.3%
For compound 4 the middle estimate is 3.3 percentage points below the measured one; low and high end bracket the measured number.
By their numbers in this assay, from the lowest: compounds 3 and 4 (each within the scatter of the next); then compounds 2 and 1 (each within the scatter of the next).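

In this assay, 3-chlorobenzyl in place of benzyl gives no change at the digits printed from compound 3 to compound 4 (within the scatter) on the core of compound 3, so this position takes a chloro there without a step beyond the scatter. Chloro in place of hydrogen on an aromatic carbon of the benzyl group can now be read on two cores, and the two steps agree: the same change on two cores in this assay, a number 5.1 percentage points lower (within the scatter) from compound 1 to compound 2 and no change at the digits printed (within the scatter) from compound 3 to compound 4, 5.1 percentage points apart, within the scatter of two such steps.

On these data alone, what a group other than chloro does on this benzyl ring stays open, for example an amine or a carboxylic acid. No step beyond the scatter is shown for any change at this position.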